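Compound 3 to Compound 4: Nitro Gives Way to Methoxy

A few compounds are considered here, and "the series" means these few. Any claim that something is new, unique, unknown or untested is made for them only; others in the source may bear on it.

Of the compounds shown here, three have so far been tested in an ADME assay on BJ cells (Homo sapiens) for antiproliferative activity, with a stated time of 72 h; a lower number here means that less compound is needed, a higher number that more compound is needed for the effect. Compound 1 `COc1ccc(-c2[nH]c3cc(OC)cc(OC)c3c(=O)c2I)cc1` reaches only a limit there, > 86200 nM. Compound 2 `COC(=O)c1cc(=O)c2cc(N)ccc2[nH]1` likewise stops at a limit, > 67200 nM. Compound 3 `COc1ccc(-c2cc(=O)c3c(OC)cc(OC)cc3n2S(=O)(=O)c2ccc([N+](=O)[O-])cc2)cc1` also gives a limit, > 29300 nM. None of the three therefore has a measured number, and compound 3 stands with the others at the edge of what this assay can report, rather than at any point on a scale.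

Compound 4 `COc1ccc(-c2cc(=O)c3c(OC)cc(OC)cc3n2S(=O)(=O)c2ccc(OC)cc2)cc1` has not yet been measured. It differs from compound 3 in one place: methoxy in place of nitro on an aromatic carbon. Going by the values given here, because compound 3 sits at the limit of > 29300 nM in this assay, at which 1 of the 3 values shown sits, no measured step is available to show how large a change of this kind can be in this assay. The step that the limit leaves unreadable from compound 3 to compound 4 is therefore expected to be small, with no direction that would stand out from the scatter. Compound 4 is estimated at 60000 nM, within a range from 15000 nM to 250000 nM, and is most likely to come back as a limit once more.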

Compound 4, half-maximal effective concentration: > 82700 nM
Compound 4: no number, only a limit; the forecaster's own chance of this, stated with the estimate: 80%; at least 1.3-fold (0.13 log units) between middle value and limit.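

Compound 3 and compound 4 both give only limits in this assay, not numbers, and the step between them, methoxy in place of nitro, cannot be read. With all four compounds shown at limits, it remains open whether any structural change here would yield a measured number in this assay.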